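The source may report more compounds than this note shows. Statements on the series, on what has been measured and on what is new or still open speak of the compounds shown alone.

Compound 1 `Cc1ccc(/N=N/N(CCCN(C)C)c2ccccc2)cc1` and compound 2 `c1ccc(/N=N/N2CCN(c3ccccc3)CC2)cc1` share a triazene core and were both tested in an ADME assay on BHK-21 cells (Mesocricetus auratus) for cytotoxicity, read by MTT assay, with a stated time of 96 h; a higher number here means that more compound is tolerated, a lower number that less compound is tolerated. For compound 1 the assay gives no number but only a limit, > 100000 nM. For compound 2 the outcome is again a limit rather than a number, > 100000 nM. Among the compounds with values here, both results therefore sit at the limit of > 100000 nM in this assay, at which 2 of the 2 values shown sit, which places compound 2 at the ceiling of what this assay reports and leaves no step between the two measured compounds to learn from.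

Compound 3 `CN1CCN(/N=N/c2ccccc2)CC1` has not yet been measured in this assay. It differs from compound 2 by methyl in place of phenyl on an amine nitrogen in a ring the change being confined to the six-membered non-aromatic ring with 2 nitrogen, while the rest of the molecule is kept.

Within the data shown here, with no measured step to lean on and both known values at the limit, the step from compound 2 to compound 3 is expected to be a number no higher from compound 2 to compound 3 (the limit leaves the size open) in this assay, that is, none beyond the usual scatter. Compound 3 is accordingly estimated at 100000 nM, with a range from 30000 nM to 300000 nM, and it is expected that the assay will most likely again return only a limit.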

Compound 3, half-maximal cytotoxic concentration: 70000 nM
The estimate for compound 3 lay 1.4-fold (0.15 log units) above the measured number, within the range that was stated.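

In this assay compound 3 is the first of the compounds shown to return a number instead of a limit, so a group on this amine nitrogen in a ring, here methyl, now has a tolerated concentration that can be read as a value. Methyl in place of phenyl at this place gives an at least 1.4-fold lower number from compound 2 to compound 3 (0.15 log units; that floor lies within the scatter); this figure is only a floor on the step and not its size, so the real difference may be as small as the usual scatter or considerably larger. The other end of the step is still a limit and not a number, as it is for one further compound: the limit of > 100000 nM in this assay, at which 2 of the 3 values shown sit.

The compounds shown leave open how the number depends on the group at this nitrogen, with only phenyl and methyl standing there, and whether an ethyl group, a benzyl group or a plain hydrogen would give a number close to that of compound 3 or return to a limit. They also leave open whether a value could be obtained for a phenyl-bearing compound at all, and with it the true size of this step.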